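The source may hold more compounds than are shown below. What is called first, only, known or untested is meant among the compounds shown, and "the series" means these compounds.

Two compounds share one core and differ only in the group carried on the nitrogen attached to that core. Compound 1 `CCCCCCCCCCCCNc1nc(SCc2ccc(C(F)(F)F)cc2)nc2ccccc12` carries a dodecyl chain there. Compound 2 `FC(F)(F)c1ccc(CSc2nc(Nc3cccc(C(F)(F)F)c3)c3ccccc3n2)cc1` carries a 3-(trifluoromethyl)phenyl group instead. Both were tested in a functional assay on MGC-803 cells (Homo sapiens) for cytotoxicity, read by MTT assay, with a stated time of 72 h; a higher number here means a weaker inhibitor, a lower number a stronger inhibitor. In this assay compound 1 reaches the assay limit of > 50000 nM, which is a limit and not a number; (the limit of > 50000 nM in this assay, at which 1 of the 2 values shown sits). In this assay, for the measured compounds named here, compound 2 gives 15100 nM, the only number among the two values shown.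

Compound 3 `COc1cc(Nc2nc(SCc3ccc(C(F)(F)F)cc3)nc3ccccc23)cc(OC)c1` has not yet been measured. It differs from compound 2 in one place: 3,5-dimethoxyphenyl in place of 3-(trifluoromethyl)phenyl on a nitrogen on an aromatic ring.

No step between two measured compounds has been recorded, so the size of the change from compound 2 to compound 3 cannot be read from any precedent among these compounds. The expectation is a modest gain in potency, about a 1.9-fold lower number from compound 2 to compound 3 (0.28 log units; within the scatter), a step only a little beyond the usual scatter. Compound 3 is therefore estimated at 8000 nM in this assay, with a plausible range from 2000 nM to 40000 nM.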

Compound 3, half-maximal inhibitory concentration: 8580 nM
Estimate against measurement, compound 3: 1.1-fold (0.03 log units) below, and the stated range covers the measured number.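

In this assay, for the compounds shown here, 3,5-dimethoxyphenyl in place of 3-(trifluoromethyl)phenyl on the nitrogen gives a 1.8-fold lower number from compound 2 to compound 3 (0.25 log units; within the scatter), the only step at this position that can be read as a number. The exchange is a real change in atoms, with carbon and oxygen in the entering group in place of carbon and fluorine in the leaving one, and hydrogen-bond acceptors where the leaving group has none, yet the heavy-atom count stays the same and this assay does not separate compound 2 from compound 3. Steps from compound 1 cannot be read, since its value is a limit and not a number: the limit of > 50000 nM in this assay, at which 1 of the 3 values shown sits.

Going by these compounds, two substituted phenyl groups say little about what this nitrogen tolerates, so it remains open whether an unsubstituted phenyl, a phenyl carrying a single methoxy, or a benzyl group would move the number beyond the scatter. On these data alone, it is equally open what a ring bearing an amine or a carboxylic acid, or an alkyl chain shorter than dodecyl, would do in this assay.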